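Removing the ortho chloro from compound 3's pendant phenyl

The source may report more compounds than this note shows. Statements on the series, on what has been measured and on what is new or still open speak of the compounds shown alone.

The series shares one core, carried here by compound 3 `Cc1nc2c3ccccc3ccc2c2nc3c(ccc4ccccc43)c(-c3ccccc3Cl)c12`. In a functional assay on HCT-116 cells (Homo sapiens) for cytotoxicity, read by MTT assay, with a stated time of 48 h (on this read-out lower numbers stand for stronger inhibition and higher numbers for weaker inhibition), compound 3 gives 48200 nM, the highest of the two numbers available, its nearest neighbour being compound 2 `Cc1nc2c3ccccc3ccc2c2nc3c(ccc4ccccc43)c(-c3ccccc3N)c12`, which in this assay gives 4760 nM. The step of a 10-fold higher number from compound 2 to compound 3 (1.01 log units; beyond the scatter) is large. Compound 1 `COc1ccc(-c2c3ccc4ccccc4c3nc3c2c(C)nc2c4ccccc4ccc32)cc1` reaches only the limit of this assay, > 80000 nM (the limit of > 80000 nM in this assay, at which 1 of the 3 values shown sits); the steps of an at least 16-fold lower number from compound 1 to compound 2 (1.22 log units; beyond the scatter) and an at least 1.6-fold lower number from compound 1 to compound 3 (0.22 log units; that floor lies within the scatter) therefore only set floors.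

Compound 4 `Cc1nc2c3ccccc3ccc2c2nc3c(ccc4ccccc43)c(-c3ccccc3)c12` differs from compound 3 by hydrogen in place of chloro on an aromatic carbon. For the measured compounds named here, no measured step removes a substituent outright; the closest are the exchange of chloro for amino, a large step, and the exchange of 2-chlorophenyl for 4-methoxyphenyl, whose floor sits within the scatter. An exchange of one small substituent for another moved the number widely, so a modest shift in either direction is plausible, with no clear lean. Compound 4 is estimated at 40000 nM, within 12000 nM to 90000 nM, a step of a 1.2-fold lower number from compound 3 to compound 4 (0.08 log units; within the scatter) being expected.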

Compound 4, half-maximal inhibitory concentration: > 80000 nM
Compound 4 ended at the assay's limit; the forecaster's own chance of this, stated with the estimate: 30%; middle value at least 2.0-fold (0.30 log units) away from the limit.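

Compound 4 joins compound 1 at a limit of this assay, not a number, so the step between these two cannot be read: the limit of > 80000 nM in this assay, at which 2 of the 4 values shown sit.

With chloro replaced by hydrogen, the step of an at least 1.6-fold higher number from compound 3 to compound 4 (0.22 log units; that floor lies within the scatter) gives only a floor, so the compounds do not yet show that chloro on this carbon counts for anything against hydrogen. The step of an at least 16-fold higher number from compound 2 to compound 4 (1.22 log units; beyond the scatter) is large, and it sets amino directly against hydrogen at this place for the first time, making amino the only substituent shown that clearly separates from plain phenyl.

As far as these compounds go, how far compound 4 lies past the limit remains unknown. Also open, from the compounds shown here alone, is whether another group on this carbon, such as hydroxy or methylamino, would track amino or stay with chloro and hydrogen.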